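A few compounds are considered here, and "the series" means these few. Any claim that something is new, unique, unknown or untested is made for them only; others in the source may bear on it.

Series notes. All four compounds share one core, carrying a sulfonamide whose nitrogen bears a heteroaryl group, and differ only in that group. Compound 1 `C=C1CC[C@@H]2[C@](C)(COC(C)=O)[C@H](OC(C)=O)CC[C@@]2(C)[C@H]1CC(Nc1ccc(S(=O)(=O)Nc2nccs2)cc1)C1=CCOC1=O` has no numerical result in a functional assay on Malme-3M cells (Homo sapiens) for inhibition, read by sulforhodamine B assay, with a stated time of 48 h; a lower number here means a stronger inhibitor of growth, a higher number a weaker inhibitor of growth: for compound 1 the entry reads "not determined" (no result reported). Compound 3 `C=C1CC[C@@H]2[C@](C)(COC(C)=O)[C@H](OC(C)=O)CC[C@@]2(C)[C@H]1CC(Nc1ccc(S(=O)(=O)Nc2ncccn2)cc1)C1=CCOC1=O` is in the same position: in this assay compound 3 reads "not determined" (no result reported). Going by the values given here, compound 2 `C=C1CC[C@@H]2[C@](C)(COC(C)=O)[C@H](OC(C)=O)CC[C@@]2(C)[C@H]1CC(Nc1ccc(S(=O)(=O)Nc2ccc(Cl)nn2)cc1)C1=CCOC1=O` is the only member with a number: in this assay compound 2 gives 1720 nM. Among the compounds with values here, it therefore stands alone as the sole point of reference, with no comparison to another measured compound possible and no step between measured compounds to draw on.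

Compound 4 `C=C1CC[C@@H]2[C@](C)(COC(C)=O)[C@H](OC(C)=O)CC[C@@]2(C)[C@H]1CC(Nc1ccc(S(=O)(=O)Nc2cc(C)on2)cc1)C1=CCOC1=O` differs from compound 2 in one place: 5-methyl-1,2-oxazol-3-yl in place of 6-chloropyridazin-3-yl on a sulfonamide nitrogen. Nothing in the series shows how a change on the sulfonamide nitrogen moves the read-out, so the size of the step can only be set by default. The expected step is a 1.2-fold higher number from compound 2 to compound 4 (0.07 log units; within the scatter), that is, no movement beyond the usual scatter in this assay, with the range kept wide in both directions to reflect the absence of any measured precedent.

For compound 4 the read-out in this assay is estimated near 2000 nM, expected to fall between 700 nM and 6000 nM.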

Compound 4, concentration for 50% growth inhibition: 1890 nM
Compound 4: middle estimate off by 1.1-fold (0.02 log units), on the high side, and the stated range covers the measured number.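

In this assay, the sulfonamide nitrogen now has its first measured step: 5-methyl-1,2-oxazol-3-yl in place of 6-chloropyridazin-3-yl gives a 1.1-fold higher number from compound 2 to compound 4 (0.04 log units; within the scatter). For this pair, then, exchanging a six-membered aromatic ring for a five-membered one, each with 2 hetero atoms and with the chlorine gone and a methyl group present, leaves the read-out within the scatter, and compound 2 is no longer the only point of reference. Nothing measured here gives a reason for this result.

Steps involving compound 1 and compound 3 cannot be read, leaving this single pair as the whole basis for judging the position, and a single pair cannot show whether the sulfonamide nitrogen tolerates change in general. Going by these compounds, it remains open whether a carboxylic acid or an amine on the heteroaryl ring, or a plain phenyl ring on the sulfonamide nitrogen, would move the number beyond the scatter, and how much of the read-out depends on the shared core rather than on this group.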